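A few compounds are considered here, and "the series" means these few. Any claim that something is new, unique, unknown or untested is made for them only; others in the source may bear on it.

Working notes on the series. Three compounds sharing one core have numbers in a functional assay on MKN-45 cells (Homo sapiens) for antiproliferative activity, read by MTT assay, with a stated time of 72 h, tested at 10 uM; a higher number here means more inhibition at the concentration tested (going by the name of the read-out), a lower number less inhibition. Compound 1 `CC(=O)Nc1cc(Oc2ccc(Nc3nccc4[nH]cc(-c5ccc(F)cc5)c(=O)c34)cc2F)ccn1` gives 77.1%, compound 2 `CC(O)C(=O)Nc1cc(Oc2ccc(Nc3nccc4[nH]cc(-c5ccc(F)cc5)c(=O)c34)cc2F)ccn1` gives 67.3%, and compound 3 `CCCC(=O)Nc1cc(Oc2ccc(Nc3nccc4[nH]cc(-c5ccc(F)cc5)c(=O)c34)cc2F)ccn1` gives 64.6%, the lowest of the three. Among the measured compounds shown here, the steps so far only vary the chain on the carbonyl carbon: a number 12.5 percentage points lower from compound 1 to compound 3 (beyond the scatter), while a number 2.7 percentage points lower from compound 2 to compound 3 (within the scatter) and a number 9.8 percentage points lower from compound 1 to compound 2 (within the scatter). Compound 4 `Nc1nccc(Oc2ccc(Nc3nccc4[nH]cc(-c5ccc(F)cc5)c(=O)c34)cc2F)c1Cl` changes a different part: 2-amino-3-chloropyridin-4-yl in place of 2-((propylcarbonyl)amino)pyridin-4-yl on an oxygen on an aromatic ring. For the measured compounds named here, no measured step touches the amide or the ring itself, so nothing measured bears directly on this change, and the size of the step in this assay cannot be read from the data; a modest movement either way would not surprise. Compound 4 is therefore expected near the series, at about 60% (range 35% to 85%), a step of a number 4.6 percentage points lower from compound 3 to compound 4 (within the scatter) being the estimate.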

Compound 4, a percentage reported as inhibition, at one concentration (the size of the read-out at that concentration, not a potency): 85.7%
For compound 4 the middle estimate is 25.7 percentage points below the measured one; measured number above the stated range.
By their numbers in this assay, from the lowest: compounds 3, 2, 1 and 4 (each within the scatter of the next, the first and the last beyond it).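

In this assay the acylated amino chain is not required for a high number at this position on the oxygen: 2-amino-3-chloropyridin-4-yl, with fewer heavy atoms and no carbonyl, gives a number 21.1 percentage points higher from compound 3 to compound 4 (beyond the scatter) and a number 18.4 percentage points higher from compound 2 to compound 4 (beyond the scatter). Against the smallest amide, the picture differs, with a number 8.6 percentage points higher from compound 1 to compound 4 (within the scatter). Nothing measured accounts for this result.

Going by these compounds, the amine and the chlorine enter together, so their separate shares in these steps stay open. On these data alone, how a bromine or a methyl in place of the chlorine would read also stays open.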